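The source may hold more compounds than are shown below. What is called first, only, known or untested is meant among the compounds shown, and "the series" means these compounds.

Measured so far:
compound 1 `CN1CCN(c2ccc(Nc3ncc4nc([S+]([O-])c5ccccc5)n(C5CC5)c4n3)cc2)CC1` — 1630 nM
compound 2 `CN1CCN(c2ccc(Nc3ncc4nc(Sc5ccccc5)n(C5CCCC5)c4n3)cc2)CC1` — 51.2 nM

In a functional assay on HCC827 cells (Homo sapiens) for antiproliferative activity, read by MTT assay, with a stated time of 72 h (a higher number here means a weaker inhibitor, a lower number a stronger inhibitor), compound 2 gives 51.2 nM, the lower of the two numbers, while compound 1 gives 1630 nM, a gap beyond the usual scatter. Compound 3 `CN1CCN(c2ccc(Nc3ncc4nc([S+]([O-])c5ccccc5)n(C5CCCC5)c4n3)cc2)CC1` differs from compound 2 in one place: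

a group of 8 heavy atoms (6 carbon, 1 oxygen, 1 sulfur; one six-membered aromatic ring of carbon only) in place of a group of 7 heavy atoms (6 carbon, 1 sulfur; one six-membered aromatic ring of carbon only), on an aromatic carbon

Among the compounds with values here, no two measured compounds differ by this change alone, so its size is not known from the data. Compound 1 carries the same entering group and gives 1630 nM, but it differs from compound 2 elsewhere as well. Compound 3 is expected to give 300 nM, somewhere between 80 nM and 1500 nM. The step of a 5.9-fold higher number from compound 2 to compound 3 (0.77 log units; beyond the scatter) is expected to run toward weaker inhibition.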

Compound 3, half-maximal inhibitory concentration: 64.7 nM
Compound 3: the middle estimate sits 4.6-fold (0.67 log units) above what was measured; measured number below the stated range.
By their numbers in this assay, from the lowest: compounds 2 and 3 (each within the scatter of the next); then compound 1.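

In this assay, placing the oxygen-bearing sulfur group in place of phenylsulfanyl on this aromatic carbon gives a 1.3-fold higher number from compound 2 to compound 3 (0.10 log units; within the scatter), so with cyclopentyl on the ring nitrogen, the two groups cannot be told apart. With the sulfur group held the same, cyclopentyl in place of cyclopropyl gives a 25-fold lower number from compound 1 to compound 3 (1.40 log units; beyond the scatter), so among these compounds the group on the nitrogen has the far larger effect. Nothing measured here explains the size of either step. Still open, on these data alone, is how an amine at this aromatic carbon, or a cyclohexyl group on the nitrogen, would compare.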